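Compound 3 to compound 4: furan-3-yl exchanged

The source may report more compounds than this note shows. Statements on the series, on what has been measured and on what is new or still open speak of the compounds shown alone.

Measured so far in a functional assay on HeLa cells (Homo sapiens) for inhibition, read by sulforhodamine B assay; a higher number here means that more compound is tolerated, a lower number that less compound is tolerated:
- compound 1 `CC1(C)CCC[C@]2(C)[C@@H](/C=C/C3=CCOC3=O)C(C=O)=CC(=O)[C@@H]12`: > 100000 nM
- compound 2 `CC1(C)CCC[C@]2(C)[C@@H](/C=C/C3=CC(=O)OC3)C(CO)=C(O)C(=O)[C@@H]12`: > 100000 nM
- compound 3 `CC1=CC(=O)[C@H]2C(C)(C)CCC[C@]2(C)[C@H]1/C=C/c1ccoc1`: 81500 nM

Within the data shown here, compound 3, at 81500 nM, holds the only actual number in the set. Compound 1 gives > 100000 nM, which is a limit of the assay and not a number. Compound 2 gives > 100000 nM, which is also a limit of the assay.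

Compound 4 `CC1=CC(=O)[C@H]2C(C)(C)CCC[C@]2(C)[C@H]1/C=C/C1=CCOC1=O` keeps the core of compound 3 and loses the furan-3-yl group: a group of 6 heavy atoms (4 carbon, 2 oxygen; one five-membered non-aromatic ring with 1 hetero atom) in place of a group of 5 heavy atoms (4 carbon, 1 oxygen; one five-membered aromatic ring with 1 hetero atom), on a double-bonded chain carbon bound to a double-bonded chain carbon. The exchange lies on a double-bonded chain carbon bound to a double-bonded chain carbon.

Among the measured compounds shown here, no step between measured compounds is available to guide the size of this change. The entering ring also occurs in compound 1, which gives the limit > 100000 nM, so no marked drop in this assay is expected. The expected step of a 1.1-fold higher number from compound 3 to compound 4 (0.04 log units; within the scatter) stays within the usual scatter, and a limit rather than a number remains possible. Compound 4 is estimated at 90000 nM, with an expected range of 40000 nM to 150000 nM.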

Compound 4, concentration lethal to 50% of the cells: > 100000 nM
Compound 4 was reported as a limit; the forecaster's own chance of this, stated with the estimate: 45%; middle value at least 1.1-fold (0.04 log units) from the limit.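

In this assay, the exchange of furan-3-yl for the non-aromatic five-membered ring, on a double-bonded chain carbon bound to a double-bonded chain carbon, gives an at least 1.2-fold higher number from compound 3 to compound 4 (0.08 log units; that floor lies within the scatter); this position therefore tolerates the change without any sign of a lower number. Compound 4 gives > 100000 nM, which is a limit of the assay and not a number. The step from compound 1 to compound 4, methyl in place of formyl on a double-bonded ring carbon, cannot be read, as both values are limits.

Going by these compounds, the true size of the exchange remains open, with most of the set sitting at a single ceiling: the limit of > 100000 nM in this assay, at which 3 of the 4 values shown sit. Also open, on these data alone, is whether an amine or a carboxylic acid at this place would give a number clearly apart from that of compound 3.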